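Swapping a Diethylamino Arm for a Difluoropiperidine Ring

A few compounds are considered here, and "the series" means these few. Any claim that something is new, unique, unknown or untested is made for them only; others in the source may bear on it.

For the measured compounds named here, compound 1 `CCN(CC)Cc1cc2c(N)nc(-c3ccco3)nc2s1` has the higher of the two numbers measured so far. In an assay on CHO-K1 cells for antagonist activity at adenosine receptor A1 (Homo sapiens), read by a beta-galactosidase reporter, with stated times of 15 min and 6 h (a higher number here means a weaker inhibitor, a lower number a stronger inhibitor), compound 1 gives 2130 nM, while compound 2 `Cc1ccc(-c2nc(N)c3cc(CN4CCCCC4)sc3n2)o1` gives 610 nM, a lower number that lies beyond the usual scatter. Compound 3 `Nc1nc(-c2ccco2)nc2sc(CN3CCC(F)(F)CC3)cc12` has not been measured yet. It carries 4,4-difluoropiperidin-1-yl in place of diethylamino on a saturated chain carbon bound to an aromatic carbon. Going by the values given here, no directly comparable pair has been measured, so the size of this step is uncertain. A modest move toward a lower number is expected, though it may also fall within the scatter. For compound 3 the estimated value is 1200 nM, with a range from 400 nM to 3500 nM. The expected step of a 1.8-fold lower number from compound 1 to compound 3 (0.25 log units; within the scatter) is small.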

Compound 3, inhibition constant: 2230 nM
The estimate for compound 3 lay 1.9-fold (0.27 log units) below the measured number; the range from low to high includes it.
By their numbers in this assay, from the lowest: compound 2; then compounds 1 and 3 (each within the scatter of the next).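

In this assay, placing 4,4-difluoropiperidin-1-yl in place of diethylamino on a saturated chain carbon bound to an aromatic carbon gives a 1.0-fold higher number from compound 1 to compound 3 (0.02 log units; within the scatter). At this place, then, an open arm with no ring and a six-membered non-aromatic ring with more heavy atoms cannot be told apart by their numbers. Nothing available explains this result.

Going by these compounds, whether a morpholine ring or a carboxylic acid at this place would shift the number remains open. On these data alone, compound 2 differs from compound 1 in more than one place, so the effect of a piperidine ring without fluorine also remains open.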